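This account rests on a few compounds, and the source may have more. Where it says the series, first, only, none or still open, it means among the compounds named here.

Four compounds are compared here, all built on one shared core and differing in the groups on one ring. Compound 1 has the structure `CCCc1c(Cl)c(O)cc(O)c1Oc1c(Cl)c(O)c(Cl)c2c1C(=O)O[C@@H]2CC`, compound 3 has the structure `CCCc1c(Cl)c(O)c(Cl)c(O)c1Oc1c(Cl)c(O)c(Cl)c2c1C(=O)O[C@@H]2CC`, compound 2 has the structure `CCCc1cc(O)cc(OC)c1Oc1c(Cl)c(O)c(Cl)c2c1C(=O)O[C@@H]2CC`, and compound 4, not yet measured, has the structure `CCCc1cc(O)c(Cl)c(OC)c1Oc1c(Cl)c(O)c(Cl)c2c1C(=O)O[C@@H]2CC`. Compound 3 arises from compound 1 by the change (chloro in place of hydrogen on an aromatic carbon). Compound 4 arises from compound 2 by the change (chloro in place of hydrogen on an aromatic carbon); this is the same kind of change, but here the place is ortho to a hydroxy group and ortho to a methoxy group, whereas from compound 1 to compound 3 it is ortho to two hydroxy groups and meta to a chloro group. How the core of compound 2 differs from the core of compound 1 is not broken down here.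

In an ADME assay on MDCK cells (Canis lupus familiaris) for cytotoxicity, read by CellTiter-Glo, with a stated time of 40 h (a higher number here means that more compound is tolerated, a lower number that less compound is tolerated), compound 1 gives > 50000 nM, which is a limit of the assay and not a number. Compound 3 gives > 50000 nM in this assay, also a limit. The step that the two limits leave unreadable from compound 1 to compound 3 therefore cannot be sized, both values sitting at the limit of > 50000 nM in this assay, at which 2 of the 3 values shown sit. Compound 2 gives > 100000 nM in this assay, again a limit, at the limit of > 100000 nM in this assay, at which 1 of the 3 values shown sits.

Because compound 2 gives > 100000 nM, a limit, compound 4 is expected to sit at a limit as well, so the expected step of a number no higher from compound 2 to compound 4 (the limit leaves the size open) is near nothing. Compound 4 is estimated at 100000 nM, within a range from 50000 nM to 200000 nM.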

Compound 4, half-maximal cytotoxic concentration: > 100000 nM
Compound 4 gave a limit, no number; the forecaster's own chance of this, stated with the estimate: 85%; the middle value lies on the limit itself.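

In this assay, compound 4 gives a limit of the assay and not a number, and so does compound 2, so no size can be read for the step between them, because both sit at the same limit: the limit of > 100000 nM in this assay, at which 2 of the 4 values shown sit.

The compounds shown leave open whether chloro in place of hydrogen on an aromatic carbon changes how much compound is tolerated, in this pair or between compound 1 and compound 3.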